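The compounds below may be only part of what the source reports. "The series", "measured", "known", "first", "only" and "open" are said of these compounds alone.

Compound 1 `CN(C(=O)NC(=O)c1ccc(F)c(F)c1)c1nc(C(F)(F)F)c(C(=O)N/N=C/c2ccc(C(F)(F)F)cc2)s1` in a functional assay on MCF7 cells (Homo sapiens) for inhibition, read by MTT assay, with a stated time of 72 h; on this read-out higher numbers stand for weaker inhibition and lower numbers for stronger inhibition: 5.93 ug/mL
Compound 2 `CN(C(=O)NC(=O)c1ccc(C(F)(F)F)cc1)c1nc(C(F)(F)F)c(C(=O)N/N=C/c2ccc(C(F)(F)F)cc2)s1` in this assay: > 100 ug/mL (a limit of the assay, not a number)
Compound 3 `CN(C(=O)NC(=O)c1c(F)cccc1F)c1nc(C(F)(F)F)c(C(=O)N/N=C/c2ccc(C(F)(F)F)cc2)s1` in this assay: 35.3 ug/mL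

Compound 2 stands at the weak end of these three, since its result is only a limit (the limit of > 100 ug/mL in this assay, at which 1 of the 3 values shown sits). Compound 4 `CN(C(=O)NC(=O)c1ccc(C(F)(F)F)cc1)c1nc(C(F)(F)F)c(C(=O)N/N=C/c2ccccc2C(F)(F)F)s1` differs from compound 2 by 2-(trifluoromethyl)phenyl in place of 4-(trifluoromethyl)phenyl on a carbon with a double bond to nitrogen. The measured steps all change the aryl group on a carbonyl carbon: an at least 16-fold higher number from compound 1 to compound 2 (1.22 log units; beyond the scatter), a 6.0-fold higher number from compound 1 to compound 3 (0.77 log units; beyond the scatter) and an at least 2.8-fold lower number from compound 2 to compound 3 (0.45 log units; beyond the scatter). None of them alters the aryl on the carbon double-bonded to nitrogen, so they offer no direct guide to this change, only a sense that such swaps can move the number a good deal. With compound 2 at a limit, compound 4 is expected to remain near that limit, with an estimated step of a number no higher from compound 2 to compound 4 (the limit leaves the size open). The estimate for compound 4 is 100 ug/mL, between 30 ug/mL and 300 ug/mL.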

Compound 4, half-maximal inhibitory concentration: 2.21 ug/mL
For compound 4 the middle estimate is 45-fold (1.66 log units) above the measured one, outside the stated range (below it).
By their numbers in this assay, from the lowest: compound 4; then compound 1; then compound 3. At a limit, above all of these: compound 2.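

In this assay, 2-(trifluoromethyl)phenyl in place of 4-(trifluoromethyl)phenyl on the carbon with a double bond to nitrogen gives an at least 45-fold lower number from compound 2 to compound 4 (1.65 log units; beyond the scatter). For the compounds shown here, the two groups hold the same atoms, joined differently, so a rearrangement alone, at a place the earlier compounds never varied, can move the number strongly. The true size of this step stays open, since the result for compound 2 is only a limit: the limit of > 100 ug/mL in this assay, at which 1 of the 4 values shown sits.

From the compounds shown here alone, whether this swap has a similar effect with the 3,4-difluorophenyl of compound 1 on the carbonyl carbon remains open. So does how a phenyl carrying an amine or a carboxylic acid would behave at this place.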